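The source may hold more compounds than are shown below. What is called first, only, known or untested is meant among the compounds shown, and "the series" means these compounds.

Going by the values given here, in a functional assay on HepG2 cells (Homo sapiens) for antiproliferative activity, read by MTT assay, with a stated time of 72 h (on this read-out lower numbers stand for stronger inhibition and higher numbers for weaker inhibition), compound 3 (`O=C(N/N=C/c1ccc(Br)cc1)Nc1ccc(Oc2ccnc3[nH]ccc23)cc1`) reads 1000 nM and compound 1 (`O=C(N/N=C/c1ccc(Br)cc1)Nc1ccc(Oc2ccnc3[nH]ccc23)c(F)c1`) reads 1000 nM so the two stand level, together the lowest of the three numbers measured so far. Compound 2 (`COc1ccc(/C=N/NC(=O)Nc2ccc(Oc3ccnc4[nH]ccc34)c(F)c2)c(OC)c1OC`) reads 2990 nM and lies higher, beyond the usual scatter.

The next compound to consider is compound 4 (`O=C(N/N=C/c1ccc(O)cc1)Nc1ccc(Oc2ccnc3[nH]ccc23)cc1`). It has hydroxy in place of bromo on an aromatic carbon, para to a large group (hydroxy in place of bromo on an aromatic carbon). Among the compounds with values here, no measured step makes this same swap, so any forecast rests on thin evidence. Within the data shown here, the only single-place step available (no change at the digits printed from compound 1 to compound 3 (within the scatter)) puts hydrogen in place of fluoro, which is a different change and says little about losing the bromo. Among the measured compounds shown here, compound 2 keeps the fluoro but has no bromo, and compound 2 at 2990 nM is the one hint that a compound without bromo can carry a higher number. It remains only a hint, since that compound differs by more than one group.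

The expected step (a 2.0-fold higher number from compound 3 to compound 4 (0.30 log units; within the scatter)) is therefore a modest rise in this assay near the edge of the scatter, and no real change remains possible. For compound 4 the estimated value is 2000 nM with an expected range from 700 nM to 6000 nM.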

Compound 4, half-maximal inhibitory concentration: 32200 nM
For compound 4 the middle estimate is 16-fold (1.21 log units) below the measured one; the measured number lies above the stated range.
By their numbers in this assay, from the lowest: compounds 1 and 3 (each within the scatter of the next); then compound 2; then compound 4.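

In this assay the change from 4-bromophenyl to 4-hydroxyphenyl gives a 32-fold higher number from compound 3 to compound 4 (1.51 log units; beyond the scatter) and so marks this carbon, para to a large group, as a place where a single swap moves the number well beyond the scatter. Going by these compounds alone, the only earlier single-place step, which reads no change at the digits printed from compound 1 to compound 3 (within the scatter) for hydrogen in place of fluoro, gave no sign that exchanging one heavy atom could matter this much. Nothing measured on these compounds bears on why the number rises, so the step stands as an observation without an explanation.

This single pair cannot separate the loss of bromo from the arrival of hydroxy, and a chloro group, an amine or plain hydrogen on the same carbon would help to show which of the two counts. It also leaves open whether hydroxy has the same large effect when the fluoro of compound 1 is kept, since the step has been read only on the fluorine-free compound 3.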